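The source may hold more compounds than are shown below. What is called first, only, known or untested is meant among the compounds shown, and "the series" means these compounds.

Measured so far in a functional assay on MDA-MB-231 cells (Homo sapiens) for cytotoxicity, read by MTT assay, with a stated time of 72 h (on this read-out higher numbers stand for weaker inhibition and lower numbers for stronger inhibition), are these compounds:
- compound 1 `CN1CCN(CCCCn2c3c(c4ccccc42)C(=O)c2c[n+]([O-])c4ccccc4c2C3=O)CC1` gives 110 nM
- compound 2 `O=C1c2c[n+]([O-])c3ccccc3c2C(=O)c2c1c1ccccc1n2CCCCN1CCCCC1` gives 610 nM
- compound 3 `O=C1c2c[n+]([O-])c3ccccc3c2C(=O)c2c1c1ccccc1n2Cc1cn([C@H]2C[C@H](O)[C@@H](CO)O2)nn1` gives 580 nM

Compound 3 cannot be told apart from compound 2, since their two numbers lie within the scatter of each other. Compound 1 shows a clearly lower number, which means stronger inhibition.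

The next molecule is compound 4 `O=C1c2c[n+]([O-])c3ccccc3c2C(=O)c2c1c1ccccc1n2Cc1cn(C[C@@H](O)CO)nn1` and it changes one group of compound 3: 2,3-dihydroxypropyl in place of 4-hydroxy-5-(hydroxymethyl)oxolan-2-yl on an aromatic nitrogen is the full count. Put simply, 2,3-dihydroxypropyl stands in place of 4-hydroxy-5-(hydroxymethyl)oxolan-2-yl on an aromatic nitrogen, so the group that enters has no ring.

Among the compounds with values here, only one measured step is available as a guide, a 5.5-fold higher number from compound 1 to compound 2 (0.74 log units; beyond the scatter) in size, and it is a modest one. It swaps a different group at a different place, so it bears on this change only loosely. It shows that a side-chain change can move the number in this assay by that much, but it gives no direction here. Within the data shown here, no measured pair tests this swap directly, so no step beyond the scatter is expected, though a modest one either way remains possible.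

The expected change is a 1.1-fold lower number from compound 3 to compound 4 (0.05 log units; within the scatter) as an estimate. For compound 4 the estimated value is 520 nM with an expected range from 200 nM to 1300 nM in this estimate.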

Compound 4, half-maximal inhibitory concentration: 670 nM
Estimate against measurement, compound 4: 1.3-fold (0.11 log units) below; measured number inside the range.
By their numbers in this assay, from the lowest: compound 1; then compounds 3, 2 and 4 (each within the scatter of the next).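

In this assay, 2,3-dihydroxypropyl stands in place of 4-hydroxy-5-(hydroxymethyl)oxolan-2-yl on an aromatic nitrogen of a five-membered aromatic ring with 3 nitrogen, and the step stays within the scatter (a 1.2-fold higher number from compound 3 to compound 4 (0.06 log units; within the scatter)), so at this position losing the ring, going from 8 to 5 heavy atoms and going from 3 defined stereocentres to 1 leaves no change that can be read, while the 2 hydrogen-bond donors remain. Compound 4 also cannot be told apart from the piperidin-1-yl compound (a 1.1-fold higher number from compound 2 to compound 4 (0.04 log units; within the scatter)), yet it remains clearly separated from compound 1 (a 6.1-fold higher number from compound 1 to compound 4 (0.78 log units; beyond the scatter)), so compound 1 is still the only one of the four set apart from the rest. Nothing measured here offers a reason for these numbers.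

The compounds shown leave open whether an amine or a carboxylic acid on that aromatic nitrogen would move the number away from those of compound 3 and compound 4. Also open, going by these compounds, is whether a longer chain bearing hydroxyl groups would do so.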